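The compounds below may be only part of what the source reports. "The series", "measured", "known", "first", "only" and "open" are said of these compounds alone.

The measured compounds:
compound 1 `C=CC1=C(C(=O)Nc2ccc(C)cc2)C(c2ccc(F)cc2)OC1`, 59200 nM in a functional assay on QGY7701 cells (Homo sapiens) for cytotoxicity, read by MTT assay, with a stated time of 24 h; on this read-out lower numbers stand for stronger inhibition and higher numbers for weaker inhibition
compound 2 `C=CC1=C(C(=O)NCc2ccccc2F)C(c2ccc(F)cc2)OC1`, 51400 nM in this assay

Compound 2 holds the lower of the two numbers in this assay, but compound 1 stands only a 1.2-fold lower number from compound 1 to compound 2 (0.06 log units; within the scatter) away, so the two sit together within the scatter and neither can be called more active. Compound 3 `C=CC1=C(C(=O)NCC(C)C)C(c2ccc(F)cc2)OC1` has not yet been measured in this assay. It differs from compound 2 by isopropyl in place of 2-fluorophenyl on a saturated chain carbon bound to an amide-type nitrogen. For the measured compounds named here, the single measured step bears on this change only loosely: a 1.2-fold lower number from compound 1 to compound 2 (0.06 log units; within the scatter) also altered the group on the amide-type nitrogen, 4-methylphenyl giving way to 2-fluorobenzyl, and the number barely moved. Going by the values given here, no measured step shows what happens when the aromatic ring at this position is exchanged for isopropyl. Among the compounds with values here, with the one prior step flat, the expected step from compound 2 to compound 3 in this assay is a 1.2-fold higher number from compound 2 to compound 3 (0.08 log units; within the scatter), no change beyond the scatter, with a slight lean towards a higher number. Compound 3 is therefore estimated at 62000 nM, within a range from 25000 nM to 150000 nM.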

Compound 3, half-maximal inhibitory concentration: > 100000 nM
Compound 3 gave a limit, no number (the forecaster's own chance of this, stated with the estimate: 20%); middle value at least 1.6-fold (0.20 log units) away from the limit.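

In this assay compound 3 gives a limit of the assay and not a number: the limit of > 100000 nM in this assay, at which 1 of the 3 values shown sits.

Isopropyl in place of 2-fluorophenyl on a saturated chain carbon bound to an amide-type nitrogen gives an at least 1.9-fold higher number from compound 2 to compound 3 (0.28 log units; that floor lies within the scatter), and isobutyl in place of 4-methylphenyl on an amide-type nitrogen gives an at least 1.6-fold higher number from compound 1 to compound 3 (0.22 log units; that floor lies within the scatter). For the compounds shown here, the earlier pair carried an aromatic ring in both groups and showed only a 1.2-fold lower number from compound 1 to compound 2 (0.06 log units; within the scatter), whereas compound 3 is the first here with no ring in this group, and its steps fix only a floor, so the change may lie within the scatter or beyond it.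

The compounds shown leave open whether the aromatic ring itself matters here, which a cyclohexylmethyl group on the amide-type nitrogen would help to separate from the isobutyl result. They also leave open how a longer chain ending in an amine or a carboxylic acid would read in this assay, and, with the shared core held constant throughout, how changes elsewhere on it would read.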